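Nitro for cyano on two cores: antiproliferative notes

The source may hold more compounds than are shown below. What is called first, only, known or untested is meant among the compounds shown, and "the series" means these compounds.

Compound 1 `CC(O)(CS(=O)(=O)c1ccc(S(F)(F)(F)(F)F)cc1)C(=O)Nc1ccc(C#N)cc1C(F)(F)F` and compound 2 `CC(O)(CS(=O)(=O)c1ccc(S(F)(F)(F)(F)F)cc1)C(=O)Nc1ccc([N+](=O)[O-])cc1C(F)(F)F` share an open-chain core; compound 3 `CC1(C)C(=O)N(c2ccc(C#N)cc2C(F)(F)F)C(=S)N1c1ccc(S(F)(F)(F)(F)F)cc1` and compound 4 `CC1(C)C(=O)N(c2ccc([N+](=O)[O-])cc2C(F)(F)F)C(=S)N1c1ccc(S(F)(F)(F)(F)F)cc1` share a cyclic core. The difference between the two cores is not broken down here. In a functional assay on CWR22R cells (Homo sapiens) for antiproliferative activity, read by propidium iodide staining, with a stated time of 96 h (a lower number here means a stronger inhibitor, a higher number a weaker inhibitor), compound 1 gives 19400 nM, compound 2 gives 18700 nM and compound 3 gives 5400 nM. Compound 3 stands lowest of the three measured numbers, with its gaps to compound 1 and to compound 2 both beyond the scatter.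

One change is made twice in the set. From compound 1 to compound 2 it is nitro in place of cyano on an aromatic carbon and it produces a 1.0-fold lower number from compound 1 to compound 2 (0.02 log units; within the scatter). From compound 3 to compound 4 it is nitro in place of cyano on an aromatic carbon, the same change at the same place, now carried out on the core of compound 3. Compound 4 has not yet been measured in this assay.

Within the data shown here, the expectation for compound 4 rests on the single measured instance of the change: because a 1.0-fold lower number from compound 1 to compound 2 (0.02 log units; within the scatter) sits within the scatter, the same change on the core of compound 3 is expected to move the number little, so the step of a 1.0-fold lower number from compound 3 to compound 4 (0.01 log units; within the scatter) is estimated to be small. Compound 4 is therefore expected to give about 5300 nM in this assay, with a range from 2500 nM to 11000 nM. That the change behaves alike on both cores is supported only by compound 1 and compound 2, and by nothing else here.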

Compound 4, half-maximal inhibitory concentration: 100000 nM
Estimate against measurement, compound 4: 19-fold (1.28 log units) below; the whole stated range lies below it.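

In this assay, nitro in place of cyano on an aromatic carbon gives a 19-fold higher number from compound 3 to compound 4 (1.27 log units; beyond the scatter), and the step on the open-chain core proved no guide to this one, so the change does not carry over between the two cores: the same change on two cores in this assay, a 1.0-fold lower number (0.02 log units; within the scatter) from compound 1 to compound 2 and a 19-fold higher number (1.27 log units; beyond the scatter) from compound 3 to compound 4, 19-fold (1.28 log units) apart, beyond the scatter of two such steps

The result shows that in this series the outcome of this single exchange depends on the core that carries it, and that a step within the scatter on one core gives no licence to assume the same on another. Among these compounds, it does not show why the two cores part ways, and it rests on only two pairs in a single cell assay, so no rule follows for any further core or for any other exchange.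

As far as these compounds go, whether a chloro group, an amine or a carboxylic acid at the same place would follow the step seen on the core of compound 1 or the one seen on the core of compound 3 remains open. Also open is which part of the difference between the two cores governs the outcome, since the two cores differ in more than one place and the compounds shown offer no intermediate between them.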